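A few compounds are considered here, and "the series" means these few. Any claim that something is new, unique, unknown or untested is made for them only; others in the source may bear on it.

Working notes on the series: in a functional assay on HL-60 cells (Homo sapiens) for cytotoxicity, read by WST assay, with a stated time of 48 h (on this read-out lower numbers stand for an effect already at smaller amounts and higher numbers for an effect only at larger amounts of compound), compound 1 `O=C1OC[C@H](Cc2ccccc2)[C@H]1Cc1ccccc1` gives 77000 nM, and compound 2 `O=C1OC[C@H](Cc2ccccc2)[C@H]1Cc1ccccc1C(F)(F)F` gives 37000 nM, the lower of the two numbers so far. The next structure is compound 3 `O=C1OC[C@H](Cc2ccccc2)[C@H]1Cc1ccccc1F`, which differs from compound 2 as follows: fluoro in place of trifluoromethyl on an aromatic carbon. This puts fluoro in place of trifluoromethyl on an aromatic carbon, ortho to a large group. For the measured compounds named here, one measured step bears on the change: a 2.1-fold lower number from compound 1 to compound 2 (0.32 log units; beyond the scatter), a modest step that adds trifluoromethyl in place of hydrogen. Going by the values given here, with only that step as a guide, a small move in this assay back toward the higher number of compound 1, 77000 nM, is expected, probably within the scatter. The expected step is a 1.5-fold higher number from compound 2 to compound 3 (0.17 log units; within the scatter). For compound 3 the estimated value is 55000 nM, with an expected range of 28000 nM to 105000 nM.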

Compound 3, half-maximal effective concentration: 72000 nM
For compound 3 the middle estimate is 1.3-fold (0.12 log units) below the measured one, within the range that was stated.
By their numbers in this assay, from the lowest: compounds 2, 3 and 1 (each within the scatter of the next, the first and the last beyond it).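

In this assay fluoro on this aromatic carbon, ortho to a large group, does not separate from hydrogen (a 1.1-fold lower number from compound 1 to compound 3 (0.03 log units; within the scatter)). Exchanging trifluoromethyl for fluoro gives a step that also stays within the scatter (a 1.9-fold higher number from compound 2 to compound 3 (0.29 log units; within the scatter)), so compound 3 cannot be told apart from either compound 1 or compound 2, although those two are separated beyond the scatter (a 2.1-fold lower number from compound 1 to compound 2 (0.32 log units; beyond the scatter)). Nothing available accounts for this pattern.

Open, as far as these compounds go, is what a chlorine atom, a methoxy group or an amine would give at this place, and whether any of them would lie further from compound 1 than trifluoromethyl does. Also open, from the compounds shown here alone, is whether a larger group such as a longer chain would move the number in this assay beyond the scatter from compound 2.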